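The source may report more compounds than this note shows. Statements on the series, on what has been measured and on what is new or still open speak of the compounds shown alone.

Measured compounds:
Compound 1 `NS(=O)(=O)NCC1CCN(c2cc(-c3ccccc3)ncn2)CC1`. In a functional assay on M21 cells (Homo sapiens) for antiproliferative activity, read by sulforhodamine B assay, with a stated time of 48 h (a lower number here means a stronger inhibitor of growth, a higher number a weaker inhibitor of growth), compound 1 gives > 100000 nM, a limit of the assay rather than a number.
Compound 2 `NS(=O)(=O)NCCC1CCN(c2cc(-c3ccccc3)ncn2)CC1`. In this assay compound 2 gives > 100000 nM, again a limit.
Compound 3 `NS(=O)(=O)NCCC1CCN(c2cc(-c3ccc(C(F)(F)F)cc3)ncn2)CC1`. In this assay compound 3 gives 34800 nM.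

Compound 2 thus sits at the limit of > 100000 nM in this assay, at which 2 of the 3 values shown sit, with no number of its own. Compound 4 `NS(=O)(=O)NCCC1CCN(c2cc(-c3ccccc3F)ncn2)CC1` differs from compound 2 in one place: fluoro in place of hydrogen on an aromatic carbon. The nearest measured step is an at least 2.8-fold lower number from compound 2 to compound 3 (0.45 log units; beyond the scatter), but that is a different group at another place on the same ring; the other step, a step that the two limits leave unreadable from compound 1 to compound 2, gives no size. Among the compounds with values here, with only that loosely related step to go on, the expected step for compound 4 is an at least 1.2-fold lower number from compound 2 to compound 4 (0.09 log units; that floor lies within the scatter), small and quite possibly still ending at a limit. Compound 4 is therefore estimated at 80000 nM, within 25000 nM to 250000 nM.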

Compound 4, concentration for 50% growth inhibition: 81800 nM
Estimate against measurement, compound 4: 1.0-fold (0.01 log units) below, and the stated range covers the measured number.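

Phenyl to 2-fluorophenyl, a single fluoro ortho to a large group, gives an at least 1.2-fold lower number from compound 2 to compound 4 (0.08 log units; that floor lies within the scatter) in this assay. So this place on the ring can take a change that yields a measured number, though that number stays weak. The true size of the step cannot be read, because compound 2 has no number of its own: the limit of > 100000 nM in this assay, at which 2 of the 4 values shown sit.

Going by these compounds, whether chloro, methyl or methoxy at this same place would match fluoro stays open. So does whether an amine there would give a step clearly beyond the scatter.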